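A few compounds are considered here, and "the series" means these few. Any claim that something is new, unique, unknown or untested is made for them only; others in the source may bear on it.

Compound 1 `CCC(=O)c1ccn(-c2ccc(S(N)(=O)=O)cc2)c1C`: 100000 nM
Compound 2 `CCC(=O)c1cc(-c2ccccc2Cl)n(-c2ccc(S(N)(=O)=O)cc2)c1C`: 38200 nM

Both values come from a physicochemical assay for solubility, read by HPLC, in phosphate buffer, measured as kinetic solubility, at pH 7.4; a higher number here means a more soluble compound, a lower number a less soluble compound. Of these two measured compounds, compound 2 has the lower number. Compound 3 `CCC(=O)c1cc(-c2ccc(Cl)cc2Cl)n(-c2ccc(S(N)(=O)=O)cc2)c1C` differs from compound 2 in one place, where 2-chlorophenyl becomes 2,4-dichlorophenyl: chloro in place of hydrogen on an aromatic carbon. The new chloro takes the place of hydrogen on an aromatic carbon, meta to a chloro group and para to a large group.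

Among the compounds with values here, only one measured step bears on this change: a 2.6-fold lower number from compound 1 to compound 2 (0.42 log units; beyond the scatter). Within the data shown here, that modest step, beyond the scatter, came with a whole 2-chlorophenyl in place of hydrogen, and no measured step shows a single chloro added alone, so the guidance is thin. A modest fall in this assay is still expected, in the same direction as that step. The expected change is a 2.2-fold lower number from compound 2 to compound 3 (0.35 log units; beyond the scatter). Compound 3 is estimated at 17000 nM, with an expected range from 6000 nM to 36000 nM.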

Compound 3, solubility: 7700 nM
For compound 3 the middle estimate is 2.2-fold (0.34 log units) above the measured one, within the range that was stated.
By their numbers in this assay, from the lowest: compound 3; then compound 2; then compound 1.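

The number in this assay responds clearly to one added chloro at this position, para to a large group: the change gives a 5.0-fold lower number from compound 2 to compound 3 (0.70 log units; beyond the scatter) and so a single atom is enough to move the result beyond the scatter. Counted from the unsubstituted position, the whole 2,4-dichlorophenyl gives a 13-fold lower number from compound 1 to compound 3 (1.11 log units; beyond the scatter) and this step is large, whereas the 2-chlorophenyl step alone was only modest. No measurement shown here explains why the number falls with this change.

On these data alone, whether a different group at this position, such as a methoxy group or an amine, would lower the number as far remains open. As far as these compounds go, it is also open whether a chloro elsewhere on this ring would give a step of the same size, or whether a carboxylic acid there would reverse the direction.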